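The source may report more compounds than this note shows. Statements on the series, on what has been measured and on what is new or still open speak of the compounds shown alone.

The study sets four compounds against one another in a functional assay (trachea) with Cavia porcellus as the target; a higher number here means that more compound is needed for the effect, a lower number that less compound is needed. Compound 1 `CCCn1c(=O)n(CCN(C)C)c(=O)c2[nH]cnc21` gives 2700 nM in this assay. Compound 2 `CCCn1c(=O)n(CCCN(C)C)c(=O)c2[nH]cnc21` carries (dimethylamino)methyl in place of dimethylamino on a saturated chain carbon, two bonds along the chain from an aromatic nitrogen and gives 20500 nM in this assay, so the step of a 7.6-fold higher number from compound 1 to compound 2 (0.88 log units; beyond the scatter) moved the read-out toward more compound being needed. Compound 3 `CCCn1c(=O)n(C)c(=O)c2c1ncn2CCN(C)C` rests on a different core, and the difference between the two cores is not broken down here. In this assay compound 3 reaches only a limit, > 100000 nM, and no number. Compound 4 `CCCn1c(=O)n(C)c(=O)c2c1ncn2CCCN(C)C` has not yet been measured in this assay; it carries the same change, ((dimethylamino)methyl in place of dimethylamino on a saturated chain carbon, two bonds along the chain from an aromatic nitrogen), that turned compound 1 into compound 2, with the same place. A rise in the read-out is expected for compound 4 because a 7.6-fold higher number from compound 1 to compound 2 (0.88 log units; beyond the scatter) went that way, and compound 3 already sits at the limit named in the limit of > 100000 nM in this assay, at which 1 of the 3 values shown sits. The step that the limit leaves unreadable from compound 3 to compound 4 is therefore expected to run beyond the limit. Compound 4 is estimated at 500000 nM, within 100000 nM to 3000000 nM, most likely reported again as a limit.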

Compound 4, half-maximal effective concentration: > 100000 nM
Compound 4 ended at the assay's limit; the forecaster's own chance of this, stated with the estimate: 90%; the middle value does not contradict the limit.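

In this assay, among the compounds shown here, compound 3 and compound 4 both stop at the same limit and neither gives a number, so no step between them can be read. The compounds shown leave open whether the change that separates compound 1 from compound 2 has any effect on the core of compound 3, and how far past the limit these two compounds lie.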